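Chloro in place of nitro: a small step expected

The source may report more compounds than this note shows. Statements on the series, on what has been measured and on what is new or still open speak of the compounds shown alone.

In a functional assay on HCT-116 cells (Homo sapiens) for antiproliferative activity, read by MTT assay, with a stated time of 72 h (on this read-out higher numbers stand for weaker inhibition and lower numbers for stronger inhibition), compound 1 `COc1ccc(/C=C2/CN(C)/C(=N/c3ccc(Br)cc3)S2)cc1` gives 8900 nM and compound 2 `COc1ccc(/C=C2/CN(C)/C(=N/c3ccc([N+](=O)[O-])cc3)S2)cc1` gives 10200 nM, so compound 2 stands level with compound 1 within the scatter. Compound 3 `COc1ccc(/C=C2/CN(C)/C(=N/c3ccc(Cl)cc3)S2)cc1` has chloro in place of nitro on an aromatic carbon. For the measured compounds named here, only one measured step bears on this change, the swap of bromo for nitro at the same place, a 1.1-fold higher number from compound 1 to compound 2 (0.06 log units; within the scatter), which stayed within the scatter. On that single step, the expected change in this assay is a 1.1-fold lower number from compound 2 to compound 3 (0.05 log units; within the scatter), nothing beyond the scatter. The estimated value for compound 3 is 9000 nM, with an expected range of 4500 nM to 18000 nM.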

Compound 3, half-maximal inhibitory concentration: 9800 nM
The estimate for compound 3 lay 1.1-fold (0.04 log units) below the measured number, and the stated range covers the measured number.
By their numbers in this assay, from the lowest: compounds 1, 3 and 2 (each within the scatter of the next).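

In this assay, chloro gives a 1.0-fold lower number from compound 2 to compound 3 (0.02 log units; within the scatter), and against bromo it gives a 1.1-fold higher number from compound 1 to compound 3 (0.04 log units; within the scatter). Bromo, nitro and chloro on this aromatic carbon therefore read alike, even though chloro brings one heavy atom where nitro brings three. Nothing measured here explains this flat result. As far as these compounds go, what remains open is whether a group of another kind at this place, such as an amine, a carboxylic acid or a longer chain, would stand level with these three. From the compounds shown here alone, whether the same holds in any other assay also remains open.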